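The source may report more compounds than this note shows. Statements on the series, on what has been measured and on what is new or still open speak of the compounds shown alone.

Series notes. Compound 1 `COc1ccccc1N1CCN(CCCNC(=O)NN(Cc2cccc(F)c2)c2ccc(F)cc2)CC1` in an assay on CHO cells for displacement of a labelled ligand from D(4) dopamine receptor (Homo sapiens), read by radioligand binding (a higher number here means a weaker inhibitor, a lower number a stronger inhibitor), gives 3.8 nM. Compound 2 `COc1ccccc1N1CCN(CCCNC(=O)NN(Cc2ccccc2)c2ccc(Br)cc2)CC1` in this assay gives 3.4 nM. Compound 3 `COc1ccc(N(Cc2cccc(F)c2)NC(=O)NCCCN2CCN(c3ccccc3OC)CC2)cc1` in this assay gives 6.2 nM, the highest of the three numbers, though its separation from compound 1 and from compound 2 stays within the scatter, so no order among the three can be read. Among the measured compounds shown here, the one step that links two measured compounds, a 1.6-fold higher number from compound 1 to compound 3 (0.21 log units; within the scatter), concerns a methoxy in place of fluoro on an aromatic carbon and is itself within the scatter.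

Compound 4 `C=CCN(NC(=O)NCCCN1CCN(c2ccccc2OC)CC1)c1ccc(OC)cc1` differs from compound 3 by vinyl in place of 3-fluorophenyl on a saturated chain carbon bound to a nitrogen on an aromatic ring. For the measured compounds named here, no measured step concerns this position or a change of this kind; the three measured compounds offer nothing that bears on it directly. With an aromatic ring leaving and only a vinyl entering, the direction in this assay is open; a moderate rise in the number is expected, with wide uncertainty. The estimate for compound 4 in this assay is 30 nM, with a range from 8 nM to 120 nM. The step this implies, a 4.8-fold higher number from compound 3 to compound 4 (0.68 log units; beyond the scatter), is expected to reach somewhat beyond the scatter.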

Compound 4, inhibition constant: 61 nM
Beside the measured number, compound 4's estimate is 2.0-fold (0.31 log units) below it; low and high end bracket the measured number.
By their numbers in this assay, from the lowest: compounds 2, 1 and 3 (each within the scatter of the next); then compound 4.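

Among the compounds shown here, at the saturated chain carbon bound to a nitrogen on an aromatic ring, the change from 3-fluorobenzyl to allyl gives the first step that lies beyond the scatter: in this assay there is a 9.8-fold higher number from compound 3 to compound 4 (0.99 log units; beyond the scatter). For the compounds shown here, this position is therefore not indifferent to its substituent, and here vinyl does not stand in for 3-fluorophenyl without a weaker number, whereas the only earlier step, a change on an aromatic carbon, stayed within the scatter. No measurement at hand explains the size of this step.

Going by these compounds, whether the aromatic ring itself matters, or only the larger group, stays open. A cyclohexylmethyl group or a longer saturated chain at this place would separate the two, and an unsubstituted benzyl group would show what the fluorine contributes.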